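A Second Chloro on the Shared Core

The source may report more compounds than this note shows. Statements on the series, on what has been measured and on what is new or still open speak of the compounds shown alone.

Compound 2 `ClCc1cccc(Cn2cnc3ncnc(Cl)c32)c1` is the starting point. In a functional assay on HCT-116 cells (Homo sapiens) for cytotoxicity, read by sulforhodamine B assay, with a stated time of 48 h (a lower number here means that less compound is tolerated, a higher number that more compound is tolerated), compound 2 gives 9540 nM, the second highest of the three numbers measured. Compound 3 `ClCc1cccc(Cn2cnc3c(Cl)ncnc32)c1` gives 6310 nM, a value within the scatter of compound 2. Compound 1 `Nc1nc(Cl)c2ncn(Cc3ccc(CCl)cc3)c2n1` differs from compound 2 in several places. In this assay compound 1 gives 56200 nM, a value beyond the scatter from that of compound 2. Compound 4 `ClCc1cccc(Cn2cnc3nc(Cl)nc(Cl)c32)c1` differs from compound 2 by chloro in place of hydrogen on an aromatic carbon. Among the measured compounds shown here, no measured pair shows this change on its own, so its size is not known from these data. Compound 4 is expected to lie close to compound 2. The estimated step is a 1.2-fold lower number from compound 2 to compound 4 (0.08 log units; within the scatter), which is to say none beyond the scatter. The value of compound 4 is estimated at 8000 nM, from 3000 nM to 25000 nM.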

Compound 4, concentration lethal to 50% of the cells: 4460 nM
For compound 4 the middle estimate is 1.8-fold (0.25 log units) above the measured one, and the stated range covers the measured number.
By their numbers in this assay, from the lowest: compounds 4, 3 and 2 (each within the scatter of the next, the first and the last beyond it); then compound 1.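

In this assay, among the compounds shown here, placing chloro in place of hydrogen on the aromatic carbon between two ring nitrogen atoms gives a 2.1-fold lower number from compound 2 to compound 4 (0.33 log units; beyond the scatter) as a modest step, the first single change that can be read in this set. This position therefore responds to substitution, although a single pair shows only a small effect. No available evidence accounts for the step.

From the compounds shown here alone, whether a methyl or methoxy group on this carbon would move the number in the same way remains open. A single pair also cannot show whether the step would hold on another core.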